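The compounds below may be only part of what the source reports. "The series", "measured", "known", "first", "only" and "open" are said of these compounds alone.

Measured compounds: compound 1 `Cc1nc(S(C)(=O)=O)ccc1Oc1ncnc(OC2CCN(C(=O)OC(C)F)CC2)c1F` gives 65.5 nM in a functional assay on isolated protein for inhibition of Glucose-dependent insulinotropic receptor (Homo sapiens), read by HTRF and cAMP accumulation; on this read-out lower numbers stand for an effect already at smaller amounts and higher numbers for an effect only at larger amounts of compound; compound 2 `CCC1(OC(=O)N2CCC(Oc3ncnc(Oc4ccc(S(C)(=O)=O)nc4C)c3F)CC2)CC1` gives 22 nM.

Compound 2 stands lowest of the two numbers; its nearest neighbour is compound 1, with a step of a 3.0-fold lower number from compound 1 to compound 2 (0.47 log units; beyond the scatter). Compound 3 `Cc1nc(S(C)(=O)=O)ccc1Oc1ncnc(OC2CCN(C(=O)OC3COC3)CC2)c1F` carries oxetan-3-yl in place of 1-ethylcyclopropyl on an oxygen next to a carbonyl group. Among the measured compounds shown here, the one measured step at this place, from compound 1 to compound 2, was modest, so the place is responsive but not decisive. For compound 3 a modest step upward is expected, a 2.5-fold higher number from compound 2 to compound 3 (0.40 log units; beyond the scatter), landing between the two known values. The estimate for compound 3 is 55 nM, within 20 nM to 150 nM.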

Compound 3, half-maximal effective concentration: 326 nM
For compound 3 the middle estimate is 5.9-fold (0.77 log units) below the measured one; the whole stated range lies below it.
By their numbers in this assay, from the lowest: compound 2; then compound 1; then compound 3.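

In this assay oxetan-3-yl brings a 15-fold higher number from compound 2 to compound 3 (1.17 log units; beyond the scatter) when it replaces 1-ethylcyclopropyl and a 5.0-fold higher number from compound 1 to compound 3 (0.70 log units; beyond the scatter) when it replaces 1-fluoroethyl, so this place on an oxygen next to a carbonyl group matters more than the first step showed. Two small rings here, the three-membered carbon ring of compound 2 and the four-membered ring of compound 3, give far apart numbers. Nothing at hand explains that gap.

The compounds shown leave open whether the high number of compound 3 goes with the ring oxygen, which a cyclobutyl group at this place would help to settle.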